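This account rests on a few compounds, and the source may have more. Where it says the series, first, only, none or still open, it means among the compounds named here.

Measured in a functional assay on a cell-free system (plasma, Homo sapiens), with a stated time of 3 min; on this read-out higher numbers stand for weaker inhibition and lower numbers for stronger inhibition:
- compound 1 `O=C(NCc1cc(Cl)ccc1-n1cnnn1)[C@@H]1CC=NN1C(=O)[C@H](O)c1ccccc1F`: 1100 nM
- compound 2 `CC(C)CC[C@@H](O)C(=O)N1N=CC[C@H]1C(=O)NCc1cc(Cl)ccc1-n1cnnn1`: 630 nM

Only these two compounds have been measured, and their values lie within the scatter of each other, so compound 2 cannot be ranked against compound 1. Compound 3 `COC(C)(C)[C@@H](O)C(=O)N1N=CC[C@H]1C(=O)NCc1cc(Cl)ccc1-n1cnnn1` keeps the core of compound 2 and carries 1-methoxy-1-methylethyl in place of isopentyl on a saturated chain carbon bound to a carbonyl carbon and an oxygen on a saturated carbon.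

Within the data shown here, one measured step bears on this change. It puts isopentyl in place of 2-fluorophenyl on that same carbon and amounts to a 1.7-fold lower number from compound 1 to compound 2 (0.24 log units; within the scatter). That exchange of a ring for a chain therefore left the read-out within the scatter. Among the measured compounds shown here, no measured compound carries 1-methoxy-1-methylethyl, so the data give no direction for the new group, and no shift beyond the scatter is expected in this assay. The expected size is a 1.1-fold higher number from compound 2 to compound 3 (0.05 log units; within the scatter). Compound 3 is estimated at 700 nM, with an expected range of 250 nM to 2000 nM.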

Compound 3, half-maximal inhibitory concentration: 3700 nM
Compound 3: the middle estimate sits 5.3-fold (0.72 log units) below what was measured, and the stated range ends below it.
By their numbers in this assay, from the lowest: compounds 2 and 1 (each within the scatter of the next); then compound 3.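

At this position, on a saturated chain carbon bound to a carbonyl carbon and an oxygen on a saturated carbon, the read-out in this assay does respond to the group carried: the exchange of isopentyl for 1-methoxy-1-methylethyl gives a 5.9-fold higher number from compound 2 to compound 3 (0.77 log units; beyond the scatter), although the earlier ring-for-chain exchange, a 1.7-fold lower number from compound 1 to compound 2 (0.24 log units; within the scatter), had stayed within the scatter. Both groups count the same number of heavy atoms and neither has a ring, so a change that swaps one carbon for an oxygen, adds one hydrogen-bond acceptor and rearranges the chain is enough to move the number, and the comparison with the ring-bearing compound points the same way, with a 3.4-fold higher number from compound 1 to compound 3 (0.53 log units; beyond the scatter). Nothing at hand explains this shift.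

Going by these compounds, what remains open is whether the higher number goes with the oxygen or with the branching at the carbon that carries the new group, a question that tert-butyl or an unbranched 3-methoxypropyl chain at this place could separate. Also open, on these data alone, is whether a hydroxyl or an amine on the chain would follow 1-methoxy-1-methylethyl or stay with isopentyl.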